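Quaternary ammonium in place of the terminal amine

A few compounds are considered here, and "the series" means these few. Any claim that something is new, unique, unknown or untested is made for them only; others in the source may bear on it.

Compound 1 `Cc1cc(C)c2cccc(OCc3c(Cl)ccc(S(=O)(=O)NC4(C(=O)N5CCN(C(=O)CCCCC[N+](C)(C)C)CC5)CCCC4)c3Cl)c2n1` gives < 10000 nM in an assay on isolated protein for binding affinity to B1 bradykinin receptor (Homo sapiens) (on this read-out lower numbers stand for stronger inhibition and higher numbers for weaker inhibition), a limit of the assay.
Compound 2 `Cc1cc(C)c2cccc(OCc3c(Cl)ccc(S(=O)(=O)NC4(C(=O)N5CCN(C(=O)C[C@@H](N)CCCN)CC5)CCCC4)c3Cl)c2n1` gives < 10000 nM in this assay, again a limit.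

The step from compound 1 to compound 2 is a step that the two limits leave unreadable from compound 1 to compound 2, its size hidden because both ends rest on (the limit of < 10000 nM in this assay, at which 2 of the 2 values shown sit). Compound 2 therefore stands only at a limit, and no number separates it from the other measured compound.

Compound 3 `Cc1cc(C)c2cccc(OCc3c(Cl)ccc(S(=O)(=O)NC4(C(=O)N5CCN(C(=O)C[C@@H](N)CCC[N+](C)(C)C)CC5)CCCC4)c3Cl)c2n1` differs from compound 2 by a group of 4 heavy atoms (3 carbon, 1 nitrogen; no ring) in place of one nitrogen atom, on a saturated chain carbon, four bonds along the chain from an amine nitrogen. Going by the values given here, the single measured step, a step that the two limits leave unreadable from compound 1 to compound 2, is the only one that bears on this change, and it offers no readable size, so no direction can be expected in this assay beyond what the limit permits. Compound 3 is accordingly estimated at 200 nM, within 5 nM to 8000 nM. The expected step is a step that the limit leaves unreadable from compound 2 to compound 3, an estimate that carries a wide range.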

Compound 3, inhibition constant: < 10000 nM
Compound 3: only a limit was reported; the forecaster's own chance of this, stated with the estimate: 60%; the middle value lies beyond the limit too.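

The steps from compound 2 to compound 3 and from compound 1 to compound 3 cannot be read in this assay, as all three compounds rest on one limit: the limit of < 10000 nM in this assay, at which 3 of the 3 values shown sit. The compounds shown leave open how far apart they truly lie in this assay.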